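This account rests on a few compounds, and the source may have more. Where it says the series, first, only, none or still open, it means among the compounds named here.

Compound 2 `O=C1/C(=C\c2cccc(Br)c2)c2ccccc2N1c1c(Cl)cccc1Cl`: 8 ug/mL
Compound 1 `O=C1/C(=C\c2ccc(F)cc2)c2ccccc2N1c1c(Cl)cccc1Cl`: 38 ug/mL

In a functional assay on B16-F10 cells (Homo sapiens) for cytotoxicity against B16-F10 (Mus musculus), read by MTT assay, with a stated time of 72 h (on this read-out lower numbers stand for an effect already at smaller amounts and higher numbers for an effect only at larger amounts of compound), compound 2 gives 8 ug/mL, the lowest of the two numbers at hand. For the measured compounds named here, compound 1 gives 38 ug/mL, and a 4.8-fold lower number from compound 1 to compound 2 (0.68 log units; beyond the scatter) is the only measured step in the set. Compound 3 `O=C1/C(=C\c2ccccc2[N+](=O)[O-])c2ccccc2N1c1c(Cl)cccc1Cl` is not yet measured; it differs from compound 2 by 2-nitrophenyl in place of 3-bromophenyl on a double-bonded chain carbon bound to a double-bonded ring carbon. Going by the values given here, no measured step makes this same exchange, so the single step from compound 1 to compound 2 bears on it only loosely: it shows that swapping one substituted phenyl for another on this carbon moved the number by a modest amount. The direction for a 2-nitrophenyl cannot be read from one step, so a change of similar or smaller size is expected, most likely a small rise. Compound 3 is therefore estimated at 15 ug/mL, within 4 ug/mL to 60 ug/mL. This expected value means a step of a 1.9-fold higher number from compound 2 to compound 3 (0.27 log units; within the scatter).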

Compound 3, concentration for half-maximal effect: > 100 ug/mL
Compound 3: only a limit was reported; the forecaster's own chance of this, stated with the estimate: 10%; at least 6.6-fold (0.82 log units) between middle value and limit.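

In this assay, for the compounds shown here, this place, on a double-bonded chain carbon bound to a double-bonded ring carbon, tolerates far less change than the one earlier step could show: 2-nitrophenyl in place of 3-bromophenyl gives an at least 12-fold higher number from compound 2 to compound 3 (1.09 log units; beyond the scatter). Set against the weaker compound of the earlier pair, 2-nitrophenyl in place of 4-fluorophenyl still gives an at least 2.6-fold higher number from compound 1 to compound 3 (0.42 log units; beyond the scatter), so compound 3 lies beyond both halogen-bearing compounds. The reading for compound 3 is a limit and not a number, so both steps give only a minimum size: the limit of > 100 ug/mL in this assay, at which 1 of the 3 values shown sits.

The compounds shown do not separate the nitro group itself from its place on the phenyl ring, as the group and its place change together. On these data alone, how an amine or a carboxylic acid on this phenyl ring would read also remains open.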